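From pyridin-3-yl to pyridin-4-yl on compound 2

The source may hold more compounds than are shown below. What is called first, only, known or untested is meant among the compounds shown, and "the series" means these compounds.

For the measured compounds named here, in a functional assay, read by Griess assay, in phosphate buffer, with a stated time of 90 min, in the presence of a further agent that is not named here (on this read-out lower numbers stand for stronger inhibition and higher numbers for weaker inhibition), compound 2 (`c1ccc(-c2[nH]c3ccccc3c2C2CC(c3cccnc3)=NN2)cc1`) gives 35 ug/mL, the lowest of the three numbers measured so far. Compound 3 (`c1ccc(-c2[nH]c3ccccc3c2C2CC(c3cccnc3)=NO2)cc1`) gives 117 ug/mL, and compound 1 (`c1ccc(-c2[nH]c3ccccc3c2C2CC(c3cccs3)=NO2)cc1`) gives 233 ug/mL.

Compound 4 (`c1ccc(-c2[nH]c3ccccc3c2C2CC(c3ccncc3)=NN2)cc1`) has the same atoms as compound 2, joined differently: pyridin-4-yl in place of pyridin-3-yl on a carbon with a double bond to nitrogen. Pyridin-4-yl stands in place of pyridin-3-yl on a carbon with a double bond to nitrogen.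

Going by the values given here, only one measured step swaps the group at this carbon: a 2.0-fold lower number from compound 1 to compound 3 (0.30 log units; within the scatter). That swap, from thiophen-2-yl to pyridin-3-yl, stayed within the scatter, but it sits on a different core from that of compound 2. Among the compounds with values here, no measurement yet compares the two pyridinyl groups directly, so this evidence is thin, and no shift beyond the scatter is expected in this assay. The expected change is a 1.1-fold higher number from compound 2 to compound 4 (0.06 log units; within the scatter), which would not go beyond the scatter.

Compound 4 is estimated at 40 ug/mL, with an expected range from 15 ug/mL to 100 ug/mL.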

Compound 4, half-maximal inhibitory concentration: 21 ug/mL
For compound 4 the middle estimate is 1.9-fold (0.28 log units) above the measured one; the measured number falls inside the stated range.
By their numbers in this assay, from the lowest: compounds 4 and 2 (each within the scatter of the next); then compounds 3 and 1 (each within the scatter of the next).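

In this assay, for the compounds shown here, the first direct comparison of the two pyridinyl groups on this carbon gives a 1.7-fold lower number from compound 2 to compound 4 (0.22 log units; within the scatter), so on the core of compound 2 these two groups cannot be told apart. The swap leaves the counts of atoms, donors and acceptors unchanged and alters only how the atoms are joined, and at this position that rearrangement produces no shift beyond the scatter. Nothing available here bears on why the two groups read alike.

As far as these compounds go, it remains open whether a quite different group on this carbon, such as an amine or a carboxylic acid, would move the number beyond the scatter on the core of compound 2. Also open, from the compounds shown here alone, is whether pyridin-4-yl would read the same as pyridin-3-yl on the core of compound 3.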